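Swapping fluoro for methylsulfanyl on the five-membered ring

The compounds below may be only part of what the source reports. "The series", "measured", "known", "first", "only" and "open" are said of these compounds alone.

Three compounds sharing an amide built from a chlorophenyl-bearing acid have been measured in a functional assay on CHO cells for agonist activity at Free fatty acid receptor 2 (Homo sapiens), read by cAMP accumulation; on this read-out higher numbers stand for weaker inhibition and lower numbers for stronger inhibition. Compound 1 `CC(C)C(C(=O)Nc1ncccn1)c1ccc(Cl)cc1` gives 53000 nM, compound 2 `CC(C)[C@H](C(=O)Nc1ncc(C(N)=O)s1)c1ccc(Cl)cc1` gives 71000 nM, and compound 3 `CC(C)(C)[C@H](C(=O)Nc1ncc(F)s1)c1ccc(Cl)cc1` gives 700 nM. Compound 3 therefore stands at the lowest number of the three, and its distance from both compound 1 and compound 2 lies well beyond the usual scatter of repeated measurements, so it is the strongest of this small set in this assay.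

Compound 4 `CSc1cnc(NC(=O)[C@H](c2ccc(Cl)cc2)C(C)(C)C)s1` keeps everything in compound 3 except one change: methylsulfanyl in place of fluoro on an aromatic carbon. Within the data shown here, no measured pair shows what this exchange does here, so no size or direction of step can be read from the data. The expectation rests only on compound 3 and its value 700 nM, with wide uncertainty, and the step from compound 3 to compound 4 is estimated as a 1.4-fold higher number from compound 3 to compound 4 (0.15 log units; within the scatter). Compound 4 is expected to give about 1000 nM, within a range from 200 nM to 5000 nM.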

Compound 4, half-maximal inhibitory concentration: 500 nM
Beside the measured number, compound 4's estimate is 2.0-fold (0.30 log units) above it, within the range that was stated.
By their numbers in this assay, from the lowest: compounds 4 and 3 (each within the scatter of the next); then compounds 1 and 2 (each within the scatter of the next).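

On the aromatic carbon next to the ring sulfur, methylsulfanyl in place of fluoro gives a step that cannot be told apart from no change (a 1.4-fold lower number from compound 3 to compound 4 (0.15 log units; within the scatter)). Among these compounds, this is the first matched pair at this position, and it shows that this assay does not separate these two groups, even though the incoming group has two heavy atoms rather than one and brings one hydrogen-bond acceptor. No evidence accompanies this result to explain it.

As far as these compounds go, what an amine, a carboxylic acid or a longer chain such as ethylsulfanyl would do on this carbon remains open. Among the compounds shown here, this exchange also appears in only one pair, so whether it gives a similar result with another group elsewhere in the molecule is unknown.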